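Piperidin-1-yl for Morpholin-4-yl on a Carbonyl Carbon

This account rests on a few compounds, and the source may have more. Where it says the series, first, only, none or still open, it means among the compounds named here.

Compound 3 `COc1ccc(/C(=C(/CCNC(=O)N2CCOCC2)c2ccccc2)c2ccccc2)cc1` is the only one of the three measured compounds to give an actual number in a functional assay on MDA-MB-231 cells (Homo sapiens) for cytotoxicity, read by MTT assay, with a stated time of 72 h (on this read-out lower numbers stand for stronger inhibition and higher numbers for weaker inhibition), where compound 3 gives 42800 nM. Compound 1 `COc1ccc(/C(=C(/CCCl)c2ccccc2)c2ccccc2)cc1` sits at the limit of the assay, > 50000 nM. Compound 2 `CCOC(=O)C(=O)NCC/C(=C(\c1ccccc1)c1ccc(OC)cc1)c1ccccc1` also sits at the limit, > 50000 nM, which is the limit of > 50000 nM in this assay, at which 2 of the 3 values shown sit. Two steps therefore lead to compound 3: an at least 1.1-fold lower number from compound 1 to compound 3 (0.06 log units; that floor lies within the scatter) and an at least 1.1-fold lower number from compound 2 to compound 3 (0.06 log units; that floor lies within the scatter). The third step, a step that the two limits leave unreadable from compound 1 to compound 2, cannot be read at all.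

Compound 4 `COc1ccc(/C(=C(/CCNC(=O)N2CCCCC2)c2ccccc2)c2ccccc2)cc1` differs from compound 3 by piperidin-1-yl in place of morpholin-4-yl on a carbonyl carbon. Among the compounds with values here, the only measured step that alters a group on that same carbonyl carbon is the one from compound 2 to compound 3, and its floor lies within the scatter, so the data give no direction for this change. The step from compound 3 to compound 4 is expected to be a 1.1-fold lower number from compound 3 to compound 4 (0.03 log units; within the scatter). Compound 4 is thus estimated at 40000 nM, in a range from 15000 nM to 100000 nM, with a real chance that the assay again reports only a limit.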

Compound 4, half-maximal inhibitory concentration: > 50000 nM
Compound 4 was reported as a limit (the forecaster's own chance of this, stated with the estimate: 45%); middle value at least 1.2-fold (0.09 log units) away from the limit.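

In this assay, within the data shown here, putting piperidin-1-yl in place of morpholin-4-yl on a carbonyl carbon gives an at least 1.1-fold higher number from compound 3 to compound 4 (0.06 log units; that floor lies within the scatter), so this is the first direct comparison of these two rings at this position, and it shows no change that can be told from the scatter. Among these compounds, compound 3 remains the only compound with an actual number, and the new result adds another limit to the set: the limit of > 50000 nM in this assay, at which 3 of the 4 values shown sit. The steps to compound 4 from compound 1 and from compound 2 have limits at both ends and cannot be read.

From the compounds shown here alone, how a piperazin-1-yl ring or a dimethylamino group on this same carbonyl carbon would read remains open. Also open, going by these compounds, is whether any group at this position can give a step clearly beyond the scatter.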